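Sulfonamide series: cyclohexyl in place of oxan-4-yl

The compounds below may be only part of what the source reports. "The series", "measured", "known", "first", "only" and "open" are said of these compounds alone.

- compound 1 `COC(=O)NC(=O)c1ccsc1NC(=O)c1ccc(S(=O)(=O)N2CCCC2)cc1`: 39.5 ug/mL
- compound 2 `COC(=O)NC(=O)c1ccsc1NC(=O)c1ccc(S(=O)(=O)N2CCC(C)CC2)cc1`: 9.13 ug/mL
- compound 3 `COC(=O)NC(=O)c1ccsc1NC(=O)c1ccc(S(=O)(=O)NC2CCOCC2)cc1`: 35.7 ug/mL

In a toxicity assay on Vero cells (Chlorocebus sabaeus) for cytotoxicity, read by MTT assay (on this read-out lower numbers stand for stronger inhibition and higher numbers for weaker inhibition), compound 3 stands level with compound 1, at a 1.1-fold lower number from compound 1 to compound 3 (0.04 log units; within the scatter), and clear of compound 2, at a 3.9-fold higher number from compound 2 to compound 3 (0.59 log units; beyond the scatter). Next comes compound 4 `COC(=O)NC(=O)c1ccsc1NC(=O)c1ccc(S(=O)(=O)NC2CCCCC2)cc1`, which has cyclohexyl in place of oxan-4-yl on a sulfonamide nitrogen. For the measured compounds named here, no measured step makes this exact change. Going by the values given here, the only guides are the other changes on the sulfonyl sulfur, and compound 2 gives the one clear drop, at a 4.3-fold lower number from compound 1 to compound 2 (0.64 log units; beyond the scatter). Compound 1 and compound 3 show that such a change can also leave the number unmoved. A modest step to a lower number is therefore expected, namely a 2.1-fold lower number from compound 3 to compound 4 (0.32 log units; beyond the scatter). Compound 4 is estimated at 17 ug/mL, with an expected range of 7 ug/mL to 38 ug/mL.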

Compound 4, half-maximal inhibitory concentration: > 64 ug/mL
Compound 4 ended at the assay's limit; the forecaster's own chance of this, stated with the estimate: 2%; middle value at least 3.7-fold (0.57 log units) away from the limit.
By their numbers in this assay, from the lowest: compound 2; then compounds 3 and 1 (each within the scatter of the next). At a limit, above all of these: compound 4.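

Compound 4 gives a limit of the read-out in this assay, not a number: the limit of > 64 ug/mL in this assay, at which 1 of the 4 values shown sits. Cyclohexyl in place of oxan-4-yl on a sulfonamide nitrogen therefore brings no lower number, though an at least 1.7-fold higher number from compound 3 to compound 4 (0.25 log units; that floor lies within the scatter) and an at least 1.6-fold higher number from compound 1 to compound 4 (0.20 log units; that floor lies within the scatter) leave any rise unsettled. Only an at least 7.0-fold higher number from compound 2 to compound 4 (0.84 log units; beyond the scatter) clears the scatter, so a carbon-only ring on this nitrogen does not reproduce the low number of compound 2.

Going by these compounds, whether that low number follows the methyl group or the ring attachment through nitrogen stays open; unsubstituted piperidin-1-yl and 4-methylcyclohexylamino on the sulfonyl sulfur would separate the two. How far compound 4 lies past its limit is also unknown.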